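The compounds below may be only part of what the source reports. "The series", "measured", "known", "first", "only" and "open" are said of these compounds alone.

Two measured compounds share one core and differ only in the group on the outer benzene ring. Compound 1 `CC(C)NC(=O)c1ccc(-c2onc3ccc(C(=O)O)cc23)cc1` gives 340 nM in an assay for inhibition of inositol hexakisphosphate kinase 3 (Homo sapiens), read by colorimetric assay, coupled enzyme assay and malachite green, with a stated time of 120 min, in the presence of a further agent that is not named here; a lower number here means a stronger inhibitor, a higher number a weaker inhibitor. Compound 2 `O=C(O)c1ccc2noc(-c3ccc(N4CCCC4=O)cc3)c2c1` gives 2170 nM in this assay, the higher of the two numbers; the step of a 6.4-fold higher number from compound 1 to compound 2 (0.80 log units; beyond the scatter) shows that swapping the amide for the ring lactam weakened inhibition. Compound 3 `O=C(O)c1ccc2noc(-c3ccc(NC(=O)C4CCCC4)cc3)c2c1` reverts toward an amide with a hydrogen-bond donor: (cyclopentylcarbonyl)amino in place of 2-oxopyrrolidin-1-yl on an aromatic carbon. For the measured compounds named here, only that one step bears on this change, so the estimate for compound 3 is a modest gain, a 2.9-fold lower number from compound 2 to compound 3 (0.46 log units; beyond the scatter), giving an expected value of 750 nM with a range from 250 nM to 2200 nM.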

Compound 3, half-maximal inhibitory concentration: 240 nM
For compound 3 the middle estimate is 3.1-fold (0.49 log units) above the measured one, outside the stated range (below it).
By their numbers in this assay, from the lowest: compounds 3 and 1 (each within the scatter of the next); then compound 2.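

Putting (cyclopentylcarbonyl)amino in place of 2-oxopyrrolidin-1-yl gives a 9.0-fold lower number from compound 2 to compound 3 (0.96 log units; beyond the scatter), so the ring lactam is not the only option at this position. Going from isopropylcarbamoyl to (cyclopentylcarbonyl)amino reverses how the amide joins the aromatic ring, yet the result is a 1.4-fold lower number from compound 1 to compound 3 (0.15 log units; within the scatter), so the two amides cannot be told apart here. Nothing measured here explains these results.

Going by these compounds, it remains open whether the amide hydrogen matters, which a methyl group on the amide nitrogen could test. A plain amine or a longer chain at this position is also untested in the compounds shown.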